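The compounds below may be only part of what the source reports. "The series", "measured", "known", "first", "only" and "open" are said of these compounds alone.

Compound 1 `CCc1cccc(CNC(=O)c2nc3cccc(COCc4ccc(C(=O)O)cc4)c3c(=O)[nH]2)c1`: > 40000 nM
Compound 2 `CCc1cccc(C(C)NC(=O)c2nc3cccc(COCc4ccc(C(=O)O)cc4)c3c(=O)[nH]2)c1`: > 20000 nM

Of the compounds shown here, two have been tested in an ADME assay on HEK293 cells (Homo sapiens) for cytotoxicity, read by resazurin assay, with a stated time of 72 h; a higher number here means that more compound is tolerated, a lower number that less compound is tolerated. Compound 1 gives > 40000 nM, and this value is a limit of the assay rather than a number. Compound 2 gives > 20000 nM, which is likewise a limit and not a number. Going by the values given here, for compound 2, then, only a limit is known, and the single other value shown for this assay is also a limit, so neither compound can be placed above or below the other. Among the compounds with values here, the one step among the measured pair, a step that the two limits leave unreadable from compound 1 to compound 2, cannot be read in size or direction, since both of its ends sit at limits, the limit of > 20000 nM in this assay, at which 1 of the 2 values shown sits, and (the limit of > 40000 nM in this assay, at which 1 of the 2 values shown sits).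

Compound 3 `CCc1ccnc(CNC(=O)c2nc3cccc(COCc4ccc(C(=O)O)cc4)c3c(=O)[nH]2)c1` is not yet measured. It differs from compound 2 by (4-ethylpyridin-2-yl)methyl in place of 1-(3-ethylphenyl)ethyl on an amide-type nitrogen. Within the data shown here, the only measured step touches the same amide-type nitrogen but gives no readable size, so it supplies no guide to the expected change in this assay. With nothing pointing either way, compound 3 is expected to sit at a limit as well, with an estimated step that the limit leaves unreadable from compound 2 to compound 3 that stays within the scatter. Compound 3 is therefore estimated at 40000 nM, ranging from 20000 nM to 80000 nM.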

Compound 3, half-maximal cytotoxic concentration: > 20000 nM
Compound 3: a limit, no number; the forecaster's own chance of this, stated with the estimate: 85%; the middle value lies beyond the limit too.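

In this assay compound 3 gives > 20000 nM, which is a limit and not a number. Going by these compounds alone, its steps from compound 1 and from compound 2 therefore cannot be read, so this result yields no new step. The compounds shown leave open what concentration of any of the three is actually tolerated, and whether exchanging the group on the amide-type nitrogen changes it.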